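Nitro for hydroxy on the anilino ring of compound 1

A few compounds are considered here, and "the series" means these few. Any claim that something is new, unique, unknown or untested is made for them only; others in the source may bear on it.

Measured so far:
compound 1 `Cn1nc(-c2ccnc(Nc3cccc(O)c3)n2)c2ccccc21`, a functional assay on HCT-116 cells (Homo sapiens) for antiproliferative activity, read by MTT assay, with a stated time of 72 h (on this read-out lower numbers stand for stronger inhibition of growth and higher numbers for weaker inhibition of growth), 17200 nM
compound 2 `Cc1ccc(Nc2nccc(-c3nn(C)c4ccccc34)n2)cc1`, 8640 nM

Compound 1 holds the highest of the two numbers; the step of a 2.0-fold lower number from compound 1 to compound 2 (0.30 log units; within the scatter) lies within the scatter, so the two compounds are not ordered. Compound 3 `Cn1nc(-c2ccnc(Nc3cccc([N+](=O)[O-])c3)n2)c2ccccc21` differs from compound 1 by nitro in place of hydroxy on an aromatic carbon. Among the compounds with values here, no measured step bears on this exact change; the only step on that phenyl group, a 2.0-fold lower number from compound 1 to compound 2 (0.30 log units; within the scatter), was within the scatter, and on that basis no step beyond the scatter is expected, a 1.3-fold lower number from compound 1 to compound 3 (0.12 log units; within the scatter). Compound 3 is estimated at 13000 nM, range 4500 nM to 40000 nM.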

Compound 3, concentration for 50% growth inhibition: 490 nM
Compound 3: middle estimate off by 27-fold (1.42 log units), on the high side; the whole stated range lies above it.
By their numbers in this assay, from the lowest: compound 3; then compounds 2 and 1 (each within the scatter of the next).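

In this assay the substituent on this phenyl ring can shift the number well beyond the scatter: nitro in place of hydroxy gives a 35-fold lower number from compound 1 to compound 3 (1.55 log units; beyond the scatter) on an aromatic carbon meta to a large group. The earlier step on this phenyl group gave a 2.0-fold lower number from compound 1 to compound 2 (0.30 log units; within the scatter) and so did not show that the ring could carry a change of this size. No measurement at hand accounts for the size of the new step.

A nitrile, an amine or a carboxylic acid on the same carbon would show whether the step is particular to nitro. On these data alone, whether nitro on another carbon of that ring gives a similar step also remains open.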